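Swapping Chloro for Bromo on Compound 2

The compounds below may be only part of what the source reports. "The series", "measured", "known", "first", "only" and "open" are said of these compounds alone.

Of the compounds shown here, two have been measured in a functional assay on HepG2 cells (Homo sapiens) for antiproliferative activity, read by sulforhodamine B assay, with a stated time of 48 h; on this read-out lower numbers stand for stronger inhibition and higher numbers for weaker inhibition. Compound 1 `COc1cc(C2=CC(c3ccc(F)cc3)NC(=S)N2)cc(OC)c1OC` gives 61.9 nM. Compound 2 `COc1cc(C2=CC(c3ccc(Cl)cc3)NC(=S)N2)cc(OC)c1OC` gives 11 nM, the lowest of the two numbers; the step of a 5.6-fold lower number from compound 1 to compound 2 (0.75 log units; beyond the scatter) came from chloro in place of fluoro on an aromatic carbon. Compound 3 `COc1cc(C2=CC(c3ccc(Br)cc3)NC(=S)N2)cc(OC)c1OC` differs from compound 2 by bromo in place of chloro on an aromatic carbon. Among the compounds with values here, only that single step offers guidance, and it concerns a different pair of halogens, so a smaller move in the same direction is expected. Compound 3 is therefore expected to show a 1.6-fold lower number from compound 2 to compound 3 (0.20 log units; within the scatter). Compound 3 is estimated at 7 nM, within a range from 2.5 nM to 22 nM.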

Compound 3, half-maximal inhibitory concentration: 9.5 nM
For compound 3 the middle estimate is 1.4-fold (0.13 log units) below the measured one, within the range that was stated.
By their numbers in this assay, from the lowest: compounds 3 and 2 (each within the scatter of the next); then compound 1.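

In this assay, bromo in place of chloro gives a 1.2-fold lower number from compound 2 to compound 3 (0.06 log units; within the scatter), so these two halogens cannot be told apart at this place on the aromatic ring. Bromo in place of fluoro gives a 6.5-fold lower number from compound 1 to compound 3 (0.81 log units; beyond the scatter), so compound 1 now differs clearly from both compound 2 and compound 3, and fluoro alone stands apart among the three halogens.

On these data alone, whether a non-halogen group such as methyl, methoxy or nitrile would fit this place as well remains open. No measurement shown here explains why compound 1 stands apart.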